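Bromo in Place of Hydroxy on the Hydrazone Ring

The source may report more compounds than this note shows. Statements on the series, on what has been measured and on what is new or still open speak of the compounds shown alone.

Measured so far in a functional assay on HepG2 cells (Homo sapiens) for inhibition, read by MTT assay, with a stated time of 48 h; a lower number here means a stronger inhibitor, a higher number a weaker inhibitor:
compound 1 `COc1ccc(/C=N/NC(=O)CSc2nnc(-c3ccncc3)n2-c2ccccc2)cc1` gives 27100 nM
compound 2 `O=C(CSc1nnc(-c2ccncc2)n1-c1ccccc1)N/N=C/c1ccc(O)cc1` gives > 50000 nM

For compound 2 that value is a limit of the assay, not a number. Compound 3 `O=C(CSc1nnc(-c2ccncc2)n1-c1ccccc1)N/N=C/c1ccc(Br)cc1` differs from it by bromo in place of hydroxy on an aromatic carbon. Among the compounds with values here, the one measured step, an at least 1.8-fold higher number from compound 1 to compound 2 (0.26 log units; that floor lies within the scatter), exchanged methyl for hydrogen on the oxygen and sits within the scatter, so it offers little guidance for taking the oxygen away altogether. Within the data shown here, no measured step bears directly on this change, and the expected step of an at least 1.6-fold lower number from compound 2 to compound 3 (0.22 log units; that floor lies within the scatter) is therefore a loose guess. Compound 3 is estimated at 30000 nM, between 8000 nM and 80000 nM.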

Compound 3, half-maximal inhibitory concentration: 5990 nM
For compound 3 the middle estimate is 5.0-fold (0.70 log units) above the measured one, and the stated range ends above it.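

Replacing the oxygen on the ring at this position separates compounds in a way that changing the group on the oxygen did not. In this assay, bromo in place of hydroxy gives an at least 8.3-fold lower number from compound 2 to compound 3 (0.92 log units; beyond the scatter), and bromo in place of methoxy gives a 4.5-fold lower number from compound 1 to compound 3 (0.66 log units; beyond the scatter). The first of these steps is only a floor, because compound 2 carries a limit and not a number: the limit of > 50000 nM in this assay, at which 1 of the 3 values shown sits.

As far as these compounds go, whether this gain belongs to bromo itself or to the loss of the oxygen stays open. A chloro group, a methyl group or an amine at this position could help to separate the two.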